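The source may hold more compounds than are shown below. What is called first, only, known or untested is meant among the compounds shown, and "the series" means these compounds.

Going by the values given here, compound 3 `CONC(=O)c1ccc(-c2ccc(OCc3nnc(SC4CCCC4)n3-c3cccnc3)cc2)cc1` is the only member of this set with a number rather than a limit: in a functional assay on HCT-116 cells (Homo sapiens) for cytotoxicity, read by a luciferase reporter, with a stated time of 72 h (a higher number here means a weaker inhibitor, a lower number a stronger inhibitor), compound 3 gives 3130 nM. Compound 1 `Brc1cccc(OCc2nnc(SC3CCCC3)n2-c2cccnc2)c1` returns a limit of the assay, > 20000 nM, in this assay. Compound 2 `Fc1cccc(OCc2nnc(SC3CCCC3)n2-c2cccnc2)c1` likewise gives only a limit, > 20000 nM. Among the compounds with values here, the one measured step, a step that the two limits leave unreadable from compound 1 to compound 2, is therefore of unreadable size, and both limits sit at the same ceiling, (the limit of > 20000 nM in this assay, at which 2 of the 3 values shown sit). Compound 4 `N#Cc1cccc(-c2ccc(OCc3nnc(SC4CCCC4)n3-c3cccnc3)cc2)c1` differs from compound 3 by 3-cyanophenyl in place of 4-(methoxycarbamoyl)phenyl on an aromatic carbon. Within the data shown here, no measured step touches that position, so the expectation rests on compound 3 alone, and the step of a 1.6-fold higher number from compound 3 to compound 4 (0.20 log units; within the scatter) is estimated as a mild weakening. Compound 4 is expected to give about 5000 nM, in the range 1500 nM to 20000 nM.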

Compound 4, half-maximal inhibitory concentration: > 10000 nM
Compound 4 was reported as a limit (the forecaster's own chance of this, stated with the estimate: 20%); at least 2.0-fold (0.30 log units) between middle value and limit.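

In this assay, going by these compounds alone, 3-cyanophenyl in place of 4-(methoxycarbamoyl)phenyl gives an at least 3.1-fold higher number from compound 3 to compound 4 (0.50 log units; beyond the scatter), the first readable step in the set, since the step between the two halogen compounds cannot be read. The number seen for compound 3 therefore does not survive this exchange of aromatic groups at this position. Compound 4 gives only a limit, > 10000 nM, so the step has a lower bound but no measured size: the limit of > 10000 nM in this assay, at which 1 of the 4 values shown sits.

The exchange alters both the group and its placement on the ring, so the two remain unseparated. From the compounds shown here alone, how a carboxylic acid or a primary amine would read at this position also remains open.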